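Compound 2 to its ring stereoisomer, compound 4

This account rests on a few compounds, and the source may have more. Where it says the series, first, only, none or still open, it means among the compounds named here.

Among the measured compounds shown here, in an ADME assay on the whole organism (strain Sprague-Dawley) for pharmacokinetics, with Rattus norvegicus as the target (a higher number here means that a larger share of the oral dose reaches the circulation, a lower number that a smaller share of the oral dose reaches the circulation), three compounds have numbers so far. Compound 1 (`CC(C)(C)[C@@H](O)C(=O)N1C[C@@H]2C[C@@H]2[C@H]1C(=O)NCc1cc(Cl)ccc1-n1cnnn1`) gives 57% and compound 3 (`CCCC[C@@H](O)C(=O)N1N=CC[C@H]1C(=O)NCc1cc(Cl)ccc1-n1cnnn1`) gives 70%. Compound 2 (`O=C(NCc1cc(Cl)ccc1-n1cnnn1)[C@@H]1C[C@H]2C[C@H]2N1C(=O)[C@H](O)c1ccccc1`) gives 86% and stands highest of the three, beyond the scatter from both others.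

Compound 4 (`O=C(NCc1cc(Cl)ccc1-n1cnnn1)[C@@H]1C[C@@H]2C[C@@H]2N1C(=O)[C@H](O)c1ccccc1`) has the same atoms and bonds as compound 2 and differs only in configuration as drawn (the two compounds have the same atoms and bonds and differ only in configuration as drawn: 2 of 4 stereo elements differ; a stereocentre at a saturated ring carbon is drawn R in compound 2 and S in compound 4; a stereocentre at a saturated ring carbon is drawn R in compound 2 and S in compound 4). At each of two saturated ring carbons, a stereocentre drawn R in compound 2 is drawn S in compound 4.

For the measured compounds named here, no measured pair in this set differs in configuration alone, so the size of this step cannot be read from the data. The expectation rests on the spread of the three numbers: compound 2 at 86% sits at the top, and the other two compounds lie lower. The expected step is a fall slightly beyond the scatter, estimated as a number 16 percentage points lower from compound 2 to compound 4 (beyond the scatter) here, and a step within the scatter remains possible. Compound 4 is expected at 70% (estimated range 45% to 90%).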

Compound 4, oral bioavailability: 63%
Compound 4: middle estimate off by 7 percentage points, on the high side; measured number inside the range.
By their numbers in this assay, from the lowest: compounds 1, 4 and 3 (each within the scatter of the next, the first and the last beyond it); then compound 2.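

In this assay, among the compounds shown here, going from R as drawn at two saturated ring carbons in compound 2 to S as drawn in compound 4 gives a number 23 percentage points lower from compound 2 to compound 4 (beyond the scatter), the first step that can be read as one change. The step can be tied to configuration alone, with nothing entering or leaving, because of one fact: the fact that compounds 2 and 4 differ only in the configuration as drawn. The earlier compounds shown here differ from each other in more than one place and could not separate ring configuration from the other changes; this pair shows that, at these two stereocentres, configuration by itself moves the oral read-out beyond the scatter.

Which of the two stereocentres carries the step stays open. Also open, on these data alone, is whether a step of this size would hold with an amine in place of the hydroxyl group.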